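Permeability notes on the glycine-amide hydroxypyridone series

The compounds below may be only part of what the source reports. "The series", "measured", "known", "first", "only" and "open" are said of these compounds alone.

Measured so far:
compound 1 `O=C(O)CNC(=O)c1c(O)c2c(n(Cc3ccc(Cl)cc3)c1=O)COC2` — 2.5 10^-6 cm/s
compound 2 `O=C(O)CNC(=O)c1c(O)c2c(n(Cc3cc(F)c(F)cc3F)c1=O)COC2` — "not determined" (no result reported)
compound 3 `O=C(O)CNC(=O)c1c(O)c2c(n(Cc3nc(C(F)(F)F)cs3)c1=O)COC2` — "not determined" (no result reported)

Compound 3 stands without a single number in an ADME assay on LLC-PK1 cells (Sus scrofa) for permeability, with a stated time of 3 h, tested at 1 uM; on this read-out lower numbers stand for lower permeability and higher numbers for higher permeability; compound 2 likewise has none, so the only anchor in the series is compound 1 at 2.5 10^-6 cm/s. Compound 4 `O=C(O)CNC(=O)c1c(O)c2c(n(Cc3nc4ccccc4o3)c1=O)COC2` differs from compound 3 by 1,3-benzoxazol-2-yl in place of 4-(trifluoromethyl)-1,3-thiazol-2-yl on a saturated chain carbon bound to an aromatic nitrogen. Among the measured compounds shown here, no measured pair in this assay is separated by this change, so the size of the step cannot be read from the data; no shift beyond the scatter is expected in either direction, but the uncertainty is wide. The expected value for compound 4 is estimated at 2.5 10^-6 cm/s, with a range from 0.8 10^-6 cm/s to 8 10^-6 cm/s.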

Compound 4, apparent permeability: < 1.9 10^-6 cm/s
Compound 4 was reported as a limit; the forecaster's own chance of this, stated with the estimate: 20%; at least 1.3-fold (0.11 log units) between middle value and limit.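

Compound 4 gives this position its first read-out with a group other than 4-chlorophenyl in this assay, and it is a limit, not a number: the limit of < 1.9 10^-6 cm/s in this assay, at which 1 of the 4 values shown sits. With 1,3-benzoxazol-2-yl in place of 4-chlorophenyl on a saturated chain carbon bound to an aromatic nitrogen, the data show an at least 1.3-fold lower number from compound 1 to compound 4 (0.11 log units; that floor lies within the scatter), so this change has no fixed size. The steps from compound 2 and compound 3 to compound 4 cannot be read.

Open, going by these compounds, is whether a single number for compound 4 would fall beyond the scatter from compound 1. Also open, on these data alone, is how a pyridin-2-yl group or a longer chain at this place would read in this assay.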